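The source may report more compounds than this note shows. Statements on the series, on what has been measured and on what is new or still open speak of the compounds shown alone.

Two compounds of this series have numbers in a functional assay on HEK293 cells for antagonist activity at thromboxane A2 receptor (Homo sapiens), read by fluorescence and calcium flux; a higher number here means a weaker inhibitor, a lower number a stronger inhibitor. Compound 1 `Cc1ccccc1Oc1ccc(C#N)cc1S(=O)(=O)NC(=O)NC(C)C` gives 8680 nM. Compound 2 `Cc1cccc(Oc2ccc(C#N)cc2S(=O)(=O)NC(=O)NC(C)C)c1` gives 2380 nM, the lowest of the two numbers; its nearest neighbour is compound 1. Within the data shown here, the single measured step, a 3.6-fold lower number from compound 1 to compound 2 (0.56 log units; beyond the scatter), exchanges 2-methylphenyl for 3-methylphenyl on the oxygen and is modest but beyond the scatter. Compound 3 `CC(C)NC(=O)NS(=O)(=O)c1cc(C#N)ccc1Oc1ccc(F)cc1` is not yet measured. Its change from compound 2 is 4-fluorophenyl in place of 3-methylphenyl on an oxygen on an aromatic ring. Among the measured compounds shown here, the only step that touches this position is the one from compound 1 to compound 2, and it concerns the swap of 2-methylphenyl for 3-methylphenyl, not the entry of a 4-fluorophenyl; it gives no direction for the present change. The expected step is therefore a 1.3-fold higher number from compound 2 to compound 3 (0.10 log units; within the scatter), not beyond the scatter. For compound 3 in this assay the estimate is 3000 nM, with a range from 1000 nM to 9000 nM.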

Compound 3, half-maximal inhibitory concentration: 9620 nM
The estimate for compound 3 lay 3.2-fold (0.51 log units) below the measured number, and the stated range ends below it.
By their numbers in this assay, from the lowest: compound 2; then compounds 1 and 3 (each within the scatter of the next).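

In this assay, the ring on the oxygen is more sensitive than the first step alone showed: a 4.0-fold higher number from compound 2 to compound 3 (0.61 log units; beyond the scatter), so a change to 4-fluorophenyl gives up the gain seen with 3-methylphenyl. Compound 2 keeps the lowest number of the three, with its steps to both others beyond the scatter. The other new step, a 1.1-fold higher number from compound 1 to compound 3 (0.04 log units; within the scatter), leaves 2-methylphenyl and 4-fluorophenyl indistinguishable here, and nothing available explains either step.

The step to compound 3 alters both the substituent and its place on the ring, so the two contributions cannot be separated; 3-fluorophenyl and 4-methylphenyl would divide them. Going by these compounds, the unsubstituted phenyl group, as a reference for all three rings, also remains open.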